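From Methyl to Isopropyl: Compound 3 and Compound 4

The source may hold more compounds than are shown below. What is called first, only, known or untested is meant among the compounds shown, and "the series" means these compounds.

In a physicochemical assay for metabolic stability, in phosphate buffer, at pH 7.4 (on this read-out higher numbers stand for a longer-lived compound and lower numbers for a shorter-lived compound), compound 3 `Cc1nc(C)c(COC(=O)N[C@H](C)C(=O)Oc2ccc(-c3cc(=O)c4c(O)c(O)c(O)cc4o3)cc2)nc1C` gives 27.8 h, while compound 2 `Cc1nc(C)c(COC(=O)NCC(=O)Oc2ccc(-c3cc(=O)c4c(O)c(O)c(O)cc4o3)cc2)nc1C` gives 14.3 h. These two values lie within the scatter of each other. Compound 1 `Cc1nc(C)c(C(=O)N[C@@H](C(=O)Oc2ccc(-c3cc(=O)c4c(O)c(O)c(O)cc4o3)cc2)C(C)C)nc1C` gives > 72 h, which is a limit of the assay and not a number.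

The next structure is compound 4 `Cc1nc(C)c(COC(=O)N[C@@H](C(=O)Oc2ccc(-c3cc(=O)c4c(O)c(O)c(O)cc4o3)cc2)C(C)C)nc1C`, which has not yet been measured. Its change from compound 3 is isopropyl in place of methyl on a saturated chain carbon bound to an amide-type nitrogen and a carbonyl carbon.

For the measured compounds named here, one measured step bears directly on this change. At the same place, methyl replaced hydrogen, and the result was a 1.9-fold higher number from compound 2 to compound 3 (0.29 log units; within the scatter). That step is small, and it gives only a weak hint of direction. Compound 1 also carries isopropyl at this place, but the rest of its structure differs from compound 4, so it offers only loose support. A modest move towards a longer half-life is therefore expected, and the step is estimated as a 2.2-fold higher number from compound 3 to compound 4 (0.33 log units; beyond the scatter). Compound 4 is expected to give about 60 h, with an estimated range from 30 h to 115 h.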

Compound 4, half-life: 45.6 h
Compound 4: the middle estimate sits 1.3-fold (0.12 log units) above what was measured; measured number inside the range.
By their numbers in this assay, from the lowest: compounds 2, 3 and 4 (each within the scatter of the next, the first and the last beyond it). At a limit, above all of these: compound 1.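

Measured in this assay, the change from methyl to isopropyl on this saturated chain carbon, bound to an amide-type nitrogen and a carbonyl carbon, stays inside the usual scatter on its own: a 1.6-fold higher number from compound 3 to compound 4 (0.21 log units; within the scatter). For the compounds shown here, the earlier hydrogen-to-methyl step also lay within the scatter, so neither single step separates its pair, but the full replacement of hydrogen by isopropyl at this place clears it, with a 3.2-fold higher number from compound 2 to compound 4 (0.50 log units; beyond the scatter), and this is the first difference at this position that can be read as real. The other new comparison, (3,5,6-trimethylpyrazin-2-yl)methoxy in place of 3,5,6-trimethylpyrazin-2-yl on a carbonyl carbon, gives an at least 1.5-fold lower number from compound 1 to compound 4 (0.19 log units; that floor lies within the scatter), which is only a floor set by a limit of the assay and not by a number: the limit of > 72 h in this assay, at which 1 of the 4 values shown sits.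

The compounds shown leave open how a longer chain, a phenyl ring or an amine at this chain carbon would stand in this assay, so three substituents give no trend that can be carried further. On these data alone, the true half-life of compound 1 also remains unknown, which leaves the change on the carbonyl carbon bounded from one side only.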